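This account rests on a few compounds, and the source may have more. Where it says the series, first, only, none or still open, it means among the compounds named here.

Compound 1 `COc1ccc(/C=C/C(=O)NCCCC(C)Nc2cc(OC)cc3cccnc23)cc1`: in an ADME assay on L6 cells (Rattus norvegicus) for cytotoxicity, read by resazurin assay, with a stated time of 70 h (on this read-out higher numbers stand for weaker inhibition and lower numbers for stronger inhibition), compound 1 gives > 100 ug/mL, a limit of the assay rather than a number.
Compound 2 `COc1cc(NC(C)CCCNC(=O)/C=C/c2cccc(C(F)(F)F)c2)c2ncccc2c1`: in this assay compound 2 gives 7.4 ug/mL.
Compound 3 `COc1cc(NC(C)CCCNC(=O)/C=C/c2ccc(C(F)(F)F)cc2)c2ncccc2c1`: in this assay compound 3 gives 73.1 ug/mL.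

Compound 1 stands at the limit (the limit of > 100 ug/mL in this assay, at which 1 of the 3 values shown sits), so only a floor is known for it. Compound 4 `COc1cc(NC(C)CCCNC(=O)Nc2ccc(O)cc2)c2ncccc2c1` differs from compound 1 by (4-hydroxyphenyl)amino in place of 2-(4-methoxyphenyl)ethenyl on a carbonyl carbon. Among the measured compounds shown here, none of the measured steps touches this part of the molecule: an at least 13-fold lower number from compound 1 to compound 2 (1.13 log units; beyond the scatter) and a 9.9-fold higher number from compound 2 to compound 3 (0.99 log units; beyond the scatter) concern where a trifluoromethyl sits on the ring, and an at least 1.3-fold lower number from compound 1 to compound 3 (0.13 log units; that floor lies within the scatter) starts from a limit and stays within the scatter. The step to compound 4 therefore has no direct precedent among these compounds. With nothing beyond the scatter pointing downward, compound 4 is expected to remain near the limit in this assay, a step of a number no higher from compound 1 to compound 4 (the limit leaves the size open). Compound 4 is estimated at 100 ug/mL, between 30 ug/mL and 300 ug/mL.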

Compound 4, half-maximal inhibitory concentration: 14.8 ug/mL
For compound 4 the middle estimate is 6.8-fold (0.83 log units) above the measured one; the whole stated range lies above it.
By their numbers in this assay, from the lowest: compounds 2 and 4 (each within the scatter of the next); then compound 3. At a limit, above all of these: compound 1.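

Placing (4-hydroxyphenyl)amino instead of 2-(4-methoxyphenyl)ethenyl on the carbonyl carbon gives an at least 6.7-fold lower number from compound 1 to compound 4 (0.82 log units; beyond the scatter), so this position, which no earlier step touched, also moves the number in this assay. Only a floor is known for the size of this change, because compound 1 stands at a limit: the limit of > 100 ug/mL in this assay, at which 1 of the 4 values shown sits.

The compounds shown do not separate the part played by the amino link from that of the hydroxy group on the ring. Nor do they show what (4-methoxyphenyl)amino would give on the same carbonyl carbon.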